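The source may hold more compounds than are shown below. What is called first, only, known or untested is meant among the compounds shown, and "the series" means these compounds.

Measured compounds:
compound 1 `O=C(Nc1cccc(Cl)c1)Nc1cc2ncncc2cc1OCc1ccccc1Cl`: 2600 nM
compound 2 `O=C(Nc1cc2ncncc2cc1OCc1ccc(Cl)cc1)Nc1cccc2ccccc12`: 7900 nM
compound 3 `O=C(Nc1cc2ncncc2cc1OCc1ccc(F)cc1)Nc1cccc2ccccc12`: 8100 nM

In a functional assay on GBM1 cells (Homo sapiens) for antiproliferative activity, read by WST assay, with a stated time of 72 h (on this read-out lower numbers stand for stronger inhibition and higher numbers for weaker inhibition), compound 1 gives the lowest of the three numbers; compound 2 and compound 3 sit higher, beyond the scatter. The difference between the core of compound 1 and the core of compound 2 is not broken down here. From compound 2 to compound 3 the change is fluoro in place of chloro on an aromatic carbon, and it gave a 1.0-fold higher number from compound 2 to compound 3 (0.01 log units; within the scatter).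

Compound 4 `O=C(Nc1cccc(F)c1)Nc1cc2ncncc2cc1OCc1ccccc1Cl` differs from compound 1 by fluoro in place of chloro on an aromatic carbon. This is the same kind of change as that from compound 2 to compound 3, but the place differs: there the fluoro sits para to a large group, here meta to a large group. Because a 1.0-fold higher number from compound 2 to compound 3 (0.01 log units; within the scatter) lay within the scatter, the step from compound 1 to compound 4 is expected to be small, about a 1.1-fold higher number from compound 1 to compound 4 (0.03 log units; within the scatter). Compound 4 is therefore estimated at 2800 nM, expected between 1300 nM and 6000 nM.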

Compound 4, half-maximal inhibitory concentration: 4000 nM
Estimate against measurement, compound 4: 1.4-fold (0.15 log units) below; the measured number falls inside the stated range.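

In this assay, fluoro in place of chloro on the core of compound 1 gave a 1.5-fold higher number from compound 1 to compound 4 (0.19 log units; within the scatter), and the two cores show no difference in how they take this change: the same change on two cores in this assay, a 1.0-fold higher number (0.01 log units; within the scatter) from compound 2 to compound 3 and a 1.5-fold higher number (0.19 log units; within the scatter) from compound 1 to compound 4, 1.5-fold (0.18 log units) apart, within the scatter of two such steps. On both cores the swap of these two halogens stays within the scatter, so in these two pairs it carries over as a change with no readable effect. This does not show that it would stay so on further cores or at other places on the rings, and two pairs give no general rule.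

Open, as far as these compounds go, is whether a group other than these two halogens at this place, such as a methoxy group, a nitrile or an amine, would move the number beyond the scatter. Also open, from the compounds shown here alone, is what a plain hydrogen there would give.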